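Methanesulfonamido to Triazolyl: Clearance Outlook for Compound 3

A few compounds are considered here, and "the series" means these few. Any claim that something is new, unique, unknown or untested is made for them only; others in the source may bear on it.

Compound 2 `COc1ccc(-c2cc(-c3ccc(NS(C)(=O)=O)cc3)cnc2N)cn1` bears a methanesulfonamido group on the shared core. In an in vitro ADME assay on microsomes from liver (Homo sapiens) for metabolic stability (a lower number here means slower removal, a higher number faster removal of the compound), compound 2 gives only a limit, < 7 mL.min-1.g-1, not a number. Compound 1 `CNS(=O)(=O)c1ccc(-c2cnc(N)c(-c3ccc(OC)nc3)c2)cc1`, which carries a methylsulfamoyl group in the same place, does give a number in this assay: compound 1 gives 9.6 mL.min-1.g-1. Within the data shown here, the single measured step, an at least 1.3-fold lower number from compound 1 to compound 2 (0.13 log units; that floor lies within the scatter), is small, and it ends at the limit of < 7 mL.min-1.g-1 in this assay, at which 1 of the 2 values shown sits, so its true size remains open.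

Compound 3 `COc1ccc(-c2cc(-c3ccc(-n4cncn4)cc3)cnc2N)cn1` differs from compound 2 in one place: 1H-1,2,4-triazol-1-yl in place of methanesulfonamido on an aromatic carbon. Among the measured compounds shown here, no measured step covers this exchange directly; the only comparison in hand concerns two sulfur-bearing groups, and it stays within the scatter while ending at a limit. On that slender basis, the step of an at least 1.1-fold higher number from compound 2 to compound 3 (0.05 log units; that floor lies within the scatter) is expected to be modest, with no clear direction beyond the scatter. Compound 3 is therefore estimated at 8 mL.min-1.g-1 in this assay, with a range running from 4 mL.min-1.g-1 to 20 mL.min-1.g-1, and a fair chance that the measurement again returns only a limit.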

Compound 3, intrinsic clearance in microsomes: 8 mL.min-1.g-1
Compound 3: middle estimate and measured number agree at the digits printed; the range from low to high includes it.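

Among these compounds, compounds 1 and 2 covered only two sulfur-bearing groups, and compound 3 extends the picture to a five-membered aromatic ring with 3 hetero atoms, carrying no sulfur and no hydrogen-bond donor, on the same aromatic carbon para to a large group. In this assay, the comparison with the methylsulfamoyl group gives a 1.2-fold lower number from compound 1 to compound 3 (0.08 log units; within the scatter), so this exchange of a sulfur-bearing group for 1H-1,2,4-triazol-1-yl leaves no change that can be told from the scatter. The comparison with the methanesulfonamido group gives only a floor, an at least 1.1-fold higher number from compound 2 to compound 3 (0.05 log units; that floor lies within the scatter), and its true size stays open because compound 2 gives a limit and not a number: the limit of < 7 mL.min-1.g-1 in this assay, at which 1 of the 3 values shown sits.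

The compounds shown leave open how other groups at this place would read, such as a primary amine, a carboxylic acid, a simple amide or a triazole joined through a carbon atom instead of a nitrogen atom. They also leave open whether 1H-1,2,4-triazol-1-yl would behave the same way if the methoxy group elsewhere on the shared core gave way to a longer alkoxy chain or an amine.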